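Replacing 2-methoxyphenyl with 4-fluorophenyl in compound 2

The source may hold more compounds than are shown below. What is called first, only, known or untested is meant among the compounds shown, and "the series" means these compounds.

In a functional assay on MCF7 cells (Homo sapiens) for inhibition, with a stated time of 48 h, tested at 50 uM (on this read-out lower numbers stand for less inhibition of growth and higher numbers for more inhibition of growth at the one concentration tested), compound 1 `C=C[C@@](C)(/C=C/c1ccc(OC(=O)CCC)cc1)CCC=C(C)C` gives 20% while compound 2 `COc1ccccc1/C=C/[C@@](C)(/C=C/c1ccc(O)cc1)CCC=C(C)C` gives 42% as the higher of the two numbers, and the gap between them lies beyond the usual scatter. Compound 3 `CC(C)=CCC[C@](C)(/C=C/c1ccc(O)cc1)/C=C/c1ccc(F)cc1` has not yet been measured. It differs from compound 2 in one place, with 4-fluorophenyl in place of 2-methoxyphenyl on a double-bonded chain carbon bound to a double-bonded chain carbon as the whole change. Going by the values given here, the two measured compounds differ in more than one place, so no measured step shows the size of such a swap. The best anchor is therefore compound 2 at 42% as its closest measured relative. The estimated step is a number 2 percentage points lower from compound 2 to compound 3 (within the scatter) and so none beyond the scatter. For compound 3 the expected value is 40% within an estimated range of 22% to 58% in this assay once it is tested.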

Compound 3, percent growth inhibition at one concentration: 28%
For compound 3 the middle estimate is 12 percentage points above the measured one; the range from low to high includes it.
By their numbers in this assay, from the lowest: compounds 1 and 3 (each within the scatter of the next); then compound 2.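

In this assay, going by these compounds alone, exchanging 2-methoxyphenyl for 4-fluorophenyl on a double-bonded chain carbon bound to a double-bonded chain carbon gives the first single-place step, a number 14 percentage points lower from compound 2 to compound 3 (beyond the scatter). This shows that the read-out responds to which group sits at this position, even though both groups contain one six-membered aromatic ring of carbon only. No available evidence bears on the reason for this step.

Because the group on the ring and its printed number both change, the step cannot say whether the ring's substituent or its location matters more, and 2-fluorophenyl or 4-methoxyphenyl at this position would separate the two. From the compounds shown here alone, it also remains open how plain phenyl or a ring bearing an amine would compare with these groups.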